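Hydroxy to acetoxy step in a halogenated lactone series

The compounds below may be only part of what the source reports. "The series", "measured", "known", "first", "only" and "open" are said of these compounds alone.

Measured compounds:
Compound 1 `CCC[C@@H](OC(C)=O)C1=C(Br)C(=C(Br)Br)OC1=O`: 1.1 ug/mL
Compound 2 `CCC[C@@H](O)C1=C(Br)C(=C(Br)Br)OC1=O`: 1.7 ug/mL
Compound 3 `CCC[C@@H](O)C1=C(Br)/C(=C/I)OC1=O`: 1.3 ug/mL

All three were tested in a functional assay on Lu1 cells (Homo sapiens) for cytotoxicity; a lower number here means that less compound is needed, a higher number that more compound is needed for the effect. Compound 2 and compound 1 differ only by acetyl in place of hydrogen on an oxygen on a saturated carbon, and that change made a 1.5-fold lower number from compound 2 to compound 1 (0.19 log units; within the scatter). Compound 3 carries a different core; the difference between the two cores is not broken down here. In this assay compound 3 gives 1.3 ug/mL, which lies within the scatter of both compound 1 and compound 2, so no order among the three can be claimed.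

Compound 4 `CCC[C@@H](OC(C)=O)C1=C(Br)/C(=C/I)OC1=O` is the counterpart of compound 3 with the same change, (acetyl in place of hydrogen on an oxygen on a saturated carbon), at the same place as in the measured pair. The step from compound 3 to compound 4 is expected to be small, a 1.4-fold lower number from compound 3 to compound 4 (0.14 log units; within the scatter), because a 1.5-fold lower number from compound 2 to compound 1 (0.19 log units; within the scatter) was itself within the scatter. Compound 4 is therefore expected to give 0.95 ug/mL, estimated between 0.5 ug/mL and 2 ug/mL.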

Compound 4, concentration for half-maximal effect: 1.5 ug/mL
The estimate for compound 4 lay 1.6-fold (0.20 log units) below the measured number; low and high end bracket the measured number.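

In this assay, hydroxy to acetoxy on the core of compound 3 gives a 1.2-fold higher number from compound 3 to compound 4 (0.06 log units; within the scatter), so this step is small on this core as well. Set beside the earlier pair, the two steps do not differ: the same change on two cores in this assay, a 1.5-fold lower number (0.19 log units; within the scatter) from compound 2 to compound 1 and a 1.2-fold higher number (0.06 log units; within the scatter) from compound 3 to compound 4, 1.8-fold (0.25 log units) apart, within the scatter of two such steps

Across these two cores, the change therefore stays within the scatter, but steps this small give it no direction, and two pairs in one assay say nothing about other cores.

Still open, on these data alone, is whether a different group on this oxygen, such as benzoyl or a carbamate bearing an amine, would give a step beyond the scatter. Also open, as far as these compounds go, is what a longer chain on the saturated carbon would do.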